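Dropping a methoxy from a bromoacrylamide inhibitor

A few compounds are considered here, and "the series" means these few. Any claim that something is new, unique, unknown or untested is made for them only; others in the source may bear on it.

Measured compounds:
- compound 1, `C=C(Br)C(=O)Nc1cccc(-c2cn3c(-c4ccc(OC)cc4)csc3n2)c1`: 200 nM
- compound 2, `C=C(Br)C(=O)Nc1cccc(-c2cn3nc(Cc4ccc(OC)cc4)sc3n2)c1`: 1400 nM
- compound 3, `Nc1cccc(-c2cn3c(-c4ccccc4)csc3n2)c1`: 85000 nM

Of the compounds shown here, three have been tested in a functional assay on L1210 cells (Mus musculus) for inhibition, read by cell counting, with a stated time of 2 days; a lower number here means a stronger inhibitor, a higher number a weaker inhibitor. Compound 1 gives 200 nM, compound 2 gives 1400 nM and compound 3 gives 85000 nM. Compound 2 thus stands second highest of the three numbers: it sits well above compound 1, by a gap beyond the scatter, and far below compound 3, again beyond the scatter. Compound 3 differs from the other two in more than one place, so its number says nothing about any single change.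

The step considered here leads from compound 2 to compound 4, `C=C(Br)C(=O)Nc1cccc(-c2cn3nc(Cc4ccccc4)sc3n2)c1`, which is not yet measured. The change is small: hydrogen in place of methoxy on an aromatic carbon. Among the measured compounds shown here, no measured pair shows this change on its own, so its effect is unknown.

A hydrogen in place of methoxy on an aromatic carbon is expected to move the number in this assay only a little, with a step of a 1.4-fold higher number from compound 2 to compound 4 (0.15 log units; within the scatter) that may still fall inside the scatter. Compound 4 is therefore estimated at 2000 nM, between 600 nM and 6000 nM.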

Compound 4, half-maximal inhibitory concentration: 3000 nM
Beside the measured number, compound 4's estimate is 1.5-fold (0.18 log units) below it, and the stated range covers the measured number.
By their numbers in this assay, from the lowest: compound 1; then compound 2; then compound 4; then compound 3.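

In this assay, among the compounds shown here, going from 4-methoxybenzyl to benzyl gives a 2.1-fold higher number from compound 2 to compound 4 (0.33 log units; beyond the scatter) and this is the first measured pair in which the methoxy changes on its own. The step is modest but real: at this position on the six-membered aromatic ring, the methoxy adds some inhibition, while compound 4 shows that inhibition does not depend on it. No measurement bears on why the step has this size.

From the compounds shown here alone, whether a hydroxyl, an amine, a chlorine atom or a longer chain such as ethoxy at this carbon would give a lower or a higher number remains open. For the compounds shown here, also open is whether going from 4-methoxyphenyl to phenyl on the core of compound 1 would give a step of similar size, since no pair here shows that change.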